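A few compounds are considered here, and "the series" means these few. Any claim that something is new, unique, unknown or untested is made for them only; others in the source may bear on it.

Measured so far:
compound 1 `O=C(N/N=C/c1ccccc1O)c1cc(-c2ccc(Cl)cc2)nn1Cc1ccc(Cl)nc1` in a functional assay on A549 cells (Homo sapiens) for cytotoxicity, read by MTT assay, with a stated time of 96 h; on this read-out lower numbers stand for stronger inhibition and higher numbers for weaker inhibition: 3680 nM
compound 2 `COc1ccc(/C=N/NC(=O)c2cc(-c3ccc(Cl)cc3)nn2Cc2ccc(Cl)nc2)cc1`: "not determined" (no result reported)

Among the measured compounds shown here, compound 1 is the only member of the series with a number in this assay, where compound 1 gives 3680 nM. Compound 2 has no result in this assay and so stands nowhere on the numbers shown; the single anchor for the series remains compound 1. Compound 3 `O=C(N/N=C/c1ccco1)c1cc(-c2ccc(Cl)cc2)nn1Cc1ccc(Cl)nc1`, not yet measured, carries the change (furan-2-yl in place of 4-methoxyphenyl on a carbon with a double bond to nitrogen), that is furan-2-yl in place of 4-methoxyphenyl on a carbon with a double bond to nitrogen. For the measured compounds named here, no measured pair shows a step of this kind, and with compound 2 unmeasured no direction can be read from the data. The expectation is therefore no shift beyond the usual scatter of this assay, the estimate resting on compound 1 because of its value 3680 nM. Compound 3 is expected to give 4000 nM in this assay, within 1500 nM to 12000 nM.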

Compound 3, half-maximal inhibitory concentration: 18700 nM
For compound 3 the middle estimate is 4.7-fold (0.67 log units) below the measured one; measured number outside the range, above it.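

In this assay the group on a carbon with a double bond to nitrogen is now shown to matter, with a 5.1-fold higher number from compound 1 to compound 3 (0.71 log units; beyond the scatter) as furan-2-yl takes the place of 2-hydroxyphenyl on an otherwise unchanged core. Of the two groups with numbers at this position, 2-hydroxyphenyl gives the lower number and so the stronger inhibition. No evidence at hand bears on the reason for this step.

The step from compound 2 to compound 3 cannot be read, which leaves 4-methoxyphenyl unplaced in the series. From the compounds shown here alone, the step from compound 1 to compound 3 changes the ring and removes the hydroxyl together, so it remains open whether unsubstituted phenyl or 2-aminophenyl at this position would keep the lower number.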